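Compound 3 to compound 4: a smaller group on the ring

This account rests on a few compounds, and the source may have more. Where it says the series, first, only, none or still open, it means among the compounds named here.

In an ADME assay on HCT-116 cells (Homo sapiens) for cytotoxicity, read by CellTiter-Glo, with a stated time of 72 h (on this read-out lower numbers stand for stronger inhibition and higher numbers for weaker inhibition), compound 1 (`Cc1cc(C)c(S(=O)(=O)N2CCC(N3CCC(Cc4ccc(F)cc4)CC3)CC2)c(C)c1`) gives > 5000 nM, which is a limit. Compound 2 (`Cc1cc(C)c(S(=O)(=O)N2CCC(N3CCC(C(C)C)CC3)CC2)c(C)c1`) gives > 5000 nM, also a limit. Compound 3 (`Cc1cc(C)c(S(=O)(=O)N2CCC(C(=O)N3CCC(C)CC3)CC2)c(C)c1`) stands at > 5000 nM, again a limit. Going by the values given here, the series so far therefore rests on (the limit of > 5000 nM in this assay, at which 3 of the 3 values shown sit).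

Compound 4 (`Cc1cc(C)c(S(=O)(=O)N2CCC(N3CCCCC3)CC2)c(C)c1`) carries piperidin-1-yl in place of (4-methylpiperidin-1-yl)carbonyl on a saturated ring carbon.

The measured steps that bear on this change are a step that the two limits leave unreadable from compound 1 to compound 2 and a step that the two limits leave unreadable from compound 2 to compound 3, and neither gives a size. No step beyond the scatter and no direction can be expected in this assay on these grounds. The estimated change is a step that the limit leaves unreadable from compound 3 to compound 4. For compound 4 the estimate is 9000 nM, with an expected range of 4000 nM to 30000 nM.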

Compound 4, half-maximal inhibitory concentration: > 5000 nM
Compound 4 gave a limit, no number; the forecaster's own chance of this, stated with the estimate: 85%; the middle value does not contradict the limit.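

No step can be read between compound 4 and compound 1, compound 2 or compound 3, because each value is a limit: the limit of > 5000 nM in this assay, at which 4 of the 4 values shown sit.

The compounds shown leave open how large these steps are and whether any group at this place gives a number rather than a limit.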